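The source may hold more compounds than are shown below. What is called first, only, known or untested is meant among the compounds shown, and "the series" means these compounds.

Measured in an ADME assay on THP-1 cells (Homo sapiens) for cytotoxicity, read by resazurin assay, with a stated time of 48 h; a lower number here means a stronger inhibitor, a higher number a weaker inhibitor:
- Compound 1 `O=c1c(O)cccn1Cc1ccccc1`: > 10 ug/mL
- Compound 2 `N#Cc1ccccc1-c1ccc(Cn2cccc(O)c2=S)cc1`: > 10 ug/mL
- Compound 3 `Cc1cccc(-c2ccc(Cn3cccc(O)c3=S)cc2)c1`: > 10 ug/mL

Compound 1 gives only a limit of the assay, > 10 ug/mL, and not an exact number. The other two entries are limits as well: the limit of > 10 ug/mL in this assay, at which 3 of the 3 values shown sit.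

Compound 4 `Cc1ccccc1-c1ccc(Cn2cccc(O)c2=O)cc1` has not been measured. It is compound 1 with one change: 2-methylphenyl in place of hydrogen on an aromatic carbon.

Among the compounds with values here, no measured pair shows this change directly, and no step beyond the scatter is expected in this assay. This expectation rests on compound 3, which also gives a limit, > 10 ug/mL. The estimated step is a step that the limit leaves unreadable from compound 1 to compound 4. For compound 4, the estimated value is 12 ug/mL, with an expected range from 5 ug/mL to 30 ug/mL.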

Compound 4, half-maximal inhibitory concentration: > 10 ug/mL
Compound 4 gave a limit, no number; the forecaster's own chance of this, stated with the estimate: 80%; the middle value is on the limit's open side.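

Compound 1 and compound 4 both give only limits, so no step can be read between them: the limit of > 10 ug/mL in this assay, at which 4 of the 4 values shown sit.

Whether the compounds shown truly differ from one another in this assay, and by how much, stays open.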